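This account rests on a few compounds, and the source may have more. Where it says the series, first, only, none or still open, it means among the compounds named here.

Working notes on the triazolopyrimidine-type series are kept here without naming the core; the shared core is visible in each structure. Three compounds have numbers in an assay on isolated protein for binding affinity to adenosine receptor A1 (Bos taurus); on this read-out lower numbers stand for stronger inhibition and higher numbers for weaker inhibition. Compound 1 `CNc1nc(-c2ccccc2)nc2c1nnn2Cc1ccccc1Cl` gives 191000000 nM in this assay. Compound 3 `CCCCNc1nc(-c2ccccc2)nc2c1nnn2Cc1ccccc1C(F)(F)F` gives 6500000 nM. Compound 2 `OC1CCC(Nc2nc(-c3ccccc3)nc3c2nnn3Cc2ccccc2F)CC1` gives 1850000 nM, the lowest of the three numbers; its nearest neighbour is compound 3, whose number is higher by a margin beyond the scatter, and compound 1 stands furthest, with a number higher by a large margin that is also beyond the scatter. For the measured compounds named here, compound 1 and compound 3 differ from compound 2 in more than one place, so no single step between measured compounds can be read from them.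

Compound 4 `Fc1ccccc1Cn1nnc2c(NC3CC3)nc(-c3ccccc3)nc21` has not been measured in this assay. It differs from compound 2 by cyclopropyl in place of 4-hydroxycyclohexyl on a nitrogen on an aromatic ring. Going by the values given here, the only smaller groups on that nitrogen in the set, in compound 1 and compound 3, sit beside other changes and give higher numbers; a weakening step is therefore expected, of about a 3.2-fold higher number from compound 2 to compound 4 (0.51 log units; beyond the scatter). Compound 4 is expected to give 6000000 nM in this assay, within a range of 1500000 nM to 30000000 nM.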

Compound 4, inhibition constant: 15000000 nM
Estimate against measurement, compound 4: 2.5-fold (0.40 log units) below; measured number inside the range.
By their numbers in this assay, from the lowest: compound 2; then compound 3; then compound 4; then compound 1.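

In this assay, for the compounds shown here, cyclopropyl in place of 4-hydroxycyclohexyl on a nitrogen on an aromatic ring gives an 8.1-fold higher number from compound 2 to compound 4 (0.91 log units; beyond the scatter), the first step that can be read at a single place, with the shared core and all other groups held constant. This shows that the group on that nitrogen can move the number by itself, which compound 1 and compound 3 could not show, as each differs from compound 2 in more than one place. No measurement shown gives a reason for this step.

The change replaces a six-membered carbon ring bearing a hydrogen-bond donor and acceptor with a three-membered ring of carbon only, so the compounds shown leave open whether the step follows the ring or the hydroxyl, a question that plain cyclohexyl or a 4-methoxycyclohexyl group on the same nitrogen would address. As far as these compounds go, it also remains open whether the step would keep its size alongside the other groups that compound 1 and compound 3 carry on the rest of the molecule.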